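This account rests on a few compounds, and the source may have more. Where it says the series, first, only, none or still open, it means among the compounds named here.

Measured in a physicochemical assay for solubility; a higher number here means a more soluble compound, a lower number a less soluble compound:
compound 1 `CNC(=O)c1cc(C(=O)NC2CC2)cn(Cc2cccc3[nH]ccc23)c1=O` gives 78 ug/mL
compound 2 `CNC(=O)c1ccc(=O)n(Cc2ccccc2)c1` gives >= 108 ug/mL, which is a limit of the assay and not a number

Compound 1 holds the only plain number shown in this assay; the remaining value is the limit (the limit of >= 108 ug/mL in this assay, at which 1 of the 2 values shown sits), so compound 1 cannot be ordered against compound 2 on these values. Within the data shown here, no pair of measured compounds differs in one place, so no measured step is available as a guide.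

Compound 3 `CNC(=O)c1cc(C(=O)NC2CC2)cn(Cc2cccc3cc[nH]c23)c1=O` is not yet measured. It differs from compound 1 as 1H-indol-7-yl in place of 1H-indol-4-yl on a saturated chain carbon bound to an aromatic nitrogen. The two compounds hold the same atoms joined differently, and the group that leaves and the group that enters are counted alike, so no step beyond the usual scatter is expected in this assay in either direction. The expected step from compound 1 to compound 3 is a 1.0-fold higher number from compound 1 to compound 3 (0.01 log units; within the scatter). Compound 3 is estimated at 80 ug/mL, with a range from 40 ug/mL to 160 ug/mL.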

Compound 3, solubility: >= 144 ug/mL
Compound 3 ended at the assay's limit (the forecaster's own chance of this, stated with the estimate: 10%); at least 1.8-fold (0.25 log units) between middle value and limit.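

In this assay, among these compounds, compound 3 gives >= 144 ug/mL, which is a limit of the assay and not a number. 1H-indol-7-yl in place of 1H-indol-4-yl on a saturated chain carbon bound to an aromatic nitrogen gives an at least 1.8-fold higher number from compound 1 to compound 3 (0.26 log units; that floor lies within the scatter), the first one-place step, and it shows that with the same atoms and the same counts in the leaving and entering groups, this change of attachment does not lower the number. Only the floor of this step can be read, so its true size stays open: the limit of >= 144 ug/mL in this assay, at which 1 of the 3 values shown sits.

The compounds shown leave open how 1H-indol-5-yl or 1H-indol-6-yl would read at the same place. They also leave open what a group of another kind, such as a carboxylic acid or a piperidine, would give there.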